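Ring Expansion on the Core Amine: What to Expect

A few compounds are considered here, and "the series" means these few. Any claim that something is new, unique, unknown or untested is made for them only; others in the source may bear on it.

Compound 1 `CC(C)/C=C/C(=O)Nc1cc2c(N3CCc4ccccc43)ncnc2cc1O[C@@H]1CCOC1` and compound 2 `CC(C)/C=C/C(=O)Nc1cc2c(N3CCCc4ccccc43)ncnc2cc1O[C@@H]1CCOC1` share one core and differ by 1,2,3,4-tetrahydroquinolin-1-yl in place of 2,3-dihydro-1H-indol-1-yl on an aromatic carbon. In a functional assay on A549 cells (Homo sapiens) for antiproliferative activity, read by MTT assay, with a stated time of 72 h (a higher number here means a weaker inhibitor, a lower number a stronger inhibitor), compound 1 gives 8520 nM, while compound 2 gives 6820 nM. Compound 3 `COc1cc2ncnc(N3CCc4ccccc43)c2cc1NC(=O)/C=C/CN(C)C` is built on a different core; the difference between the two cores is not broken down here. In this assay compound 3 gives 2040 nM, the lowest of the three numbers and beyond the scatter from both of the others. Compound 4 `COc1cc2ncnc(N3CCCc4ccccc43)c2cc1NC(=O)/C=C/CN(C)C` has not yet been measured; it differs from compound 3 by 1,2,3,4-tetrahydroquinolin-1-yl in place of 2,3-dihydro-1H-indol-1-yl on an aromatic carbon, at the same place as in the earlier pair, so it is the same change. Because the earlier step of a 1.2-fold lower number from compound 1 to compound 2 (0.10 log units; within the scatter) stayed within the scatter, the expected change is a 1.2-fold lower number from compound 3 to compound 4 (0.08 log units; within the scatter). Compound 4 is therefore estimated at 1700 nM, with a range from 700 nM to 4200 nM.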

Compound 4, half-maximal inhibitory concentration: 1650 nM
Beside the measured number, compound 4's estimate is 1.0-fold (0.01 log units) above it; low and high end bracket the measured number.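

In this assay, putting 1,2,3,4-tetrahydroquinolin-1-yl in place of 2,3-dihydro-1H-indol-1-yl gives a 1.2-fold lower number from compound 3 to compound 4 (0.09 log units; within the scatter). Carried from one core to the other, the change behaves alike, and neither step stands clear of the scatter: the same change on two cores in this assay, a 1.2-fold lower number (0.10 log units; within the scatter) from compound 1 to compound 2 and a 1.2-fold lower number (0.09 log units; within the scatter) from compound 3 to compound 4, 1.0-fold (0.00 log units) apart, within the scatter of two such steps. This shows that on these two cores the exchange leaves the number within the scatter, but it does not show that the change has any effect of its own, nor that a change with a larger step would carry over in the same way.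

The compounds shown leave open whether other amines at this place, such as morpholine or open-chain N-methylaniline, would behave as these two do. They also leave open whether the two steps would still match on a core with a longer chain on the amide.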